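A few compounds are considered here, and "the series" means these few. Any claim that something is new, unique, unknown or untested is made for them only; others in the source may bear on it.

Measured in a functional assay on MIA PaCa-2 cells (Homo sapiens) for cytotoxicity, read by WST assay, with a stated time of 48 h; a lower number here means a stronger inhibitor, a higher number a weaker inhibitor:
- compound 1 `N#C/C(=C\c1c[nH]c2ccccc12)C(=O)c1c[nH]c2ccccc12`: 36800 nM
- compound 2 `COc1ccc(Cn2cc(/C=C(\C#N)C(=O)c3c[nH]c4cc(F)ccc34)c3ccccc32)cc1`: 29400 nM

Only these two numbers exist so far. Compound 2, at 29400 nM, lies within the usual scatter of compound 1, at 36800 nM, so this assay does not separate them. Neither can be ranked above the other.

The next compound is compound 3 `COc1ccc(Cn2cc(/C=C(\C#N)C(=O)c3c[nH]c4ccccc34)c3ccccc32)cc1`. It keeps the structure of compound 2, with hydrogen in place of fluoro on an aromatic carbon. Cut one bond further out, the same difference reads 6-fluoro-1H-indol-3-yl to 1H-indol-3-yl.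

Going by the values given here, no measured pair isolates this single change, so there is no direct precedent for its size or direction. Among the compounds with values here, the only guide is that compound 1 and compound 2 differ in more than one place, yet their values stay within the scatter of each other. The change here is a single atom, so no large shift is expected. The estimated 1.1-fold lower number from compound 2 to compound 3 (0.02 log units; within the scatter) stays within the scatter, with no firm direction. For compound 3, the estimated value is 28000 nM, with an expected range of 10000 nM to 70000 nM.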

Compound 3, half-maximal inhibitory concentration: > 50000 nM
Compound 3 gave a limit, no number; the forecaster's own chance of this, stated with the estimate: 15%; middle value at least 1.7-fold (0.25 log units) from the limit.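

In this assay compound 3 gives > 50000 nM, which is a limit of the assay and not a number. Going by these compounds alone, this supplies the first comparison that isolates the fluoro on the 6-fluoro-1H-indol-3-yl group: with hydrogen in place of fluoro on that aromatic carbon, the result is an at least 1.7-fold higher number from compound 2 to compound 3 (0.23 log units; that floor lies within the scatter), so only a floor is known for this change, and because that floor lies within the scatter, it does not establish that the fluoro matters. It also isolates the 4-methoxybenzyl group, in place of hydrogen on an aromatic nitrogen, as an at least 1.3-fold higher number from compound 1 to compound 3 (0.13 log units; that floor lies within the scatter), again only a floor within the scatter, and both steps rest on the same single reading: the limit of > 50000 nM in this assay, at which 1 of the 3 values shown sits.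

On these data alone, the true size of each change remains open, since a limit sets only where the value of compound 3 begins and not where it lies. Also open, as far as these compounds go, is how a chloro or methoxy group on that same aromatic carbon, or a longer chain or an amine in place of the 4-methoxybenzyl group on the nitrogen, would read in this assay.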